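Amide aryl swap in a weakly antiproliferative series

The source may report more compounds than this note shows. Statements on the series, on what has been measured and on what is new or still open speak of the compounds shown alone.

Measured compounds in a functional assay on HeLa cells (Homo sapiens) for antiproliferative activity, read by MTT assay, with a stated time of 72 h; on this read-out lower numbers stand for stronger inhibition and higher numbers for weaker inhibition:
compound 1 `O=C(Nc1ccc(Cl)c(-c2nnc3c(Cl)cccn23)c1)c1ccc(C(F)(F)F)cc1Cl`: a limit, > 100000 nM
compound 2 `O=C(Nc1ccc(Cl)c(-c2nnc3c(Cl)cccn23)c1)c1cccnc1`: a limit, > 100000 nM
compound 3 `O=C(Nc1ccc(Cl)c(-c2nnc3c(Cl)cccn23)c1)c1ccc(C(F)(F)F)cc1F`: 61900 nM

Compound 2 sits at the limit of > 100000 nM in this assay, at which 2 of the 3 values shown sit, so only a limit and no number is known for it. Within the data shown here, the single measured step, an at least 1.6-fold lower number from compound 1 to compound 3 (0.20 log units; that floor lies within the scatter), lies within the scatter and concerns a different part of the molecule. Among the measured compounds shown here, the change leading to compound 4 `CS(=O)(=O)c1ccc(C(=O)Nc2ccc(Cl)c(-c3nnc4c(Cl)cccn34)c2)cc1` is 4-(methylsulfonyl)phenyl in place of pyridin-3-yl on a carbonyl carbon; no measured step touches this position, so the size of the step in this assay cannot be read from the data. Compound 4 is therefore expected to remain near the same limit, with a number no higher from compound 2 to compound 4 (the limit leaves the size open) estimated as no step beyond the scatter. The estimate for compound 4 is 100000 nM, between 40000 nM and 300000 nM.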

Compound 4, half-maximal inhibitory concentration: > 100000 nM
Compound 4 was reported as a limit; the forecaster's own chance of this, stated with the estimate: 60%; the middle value lies on the limit itself.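

Compound 2 and compound 4 are both reported as limits, not numbers, so no step between them can be read: the limit of > 100000 nM in this assay, at which 3 of the 4 values shown sit.

The compounds shown leave open whether pyridin-3-yl or 4-(methylsulfonyl)phenyl on the carbonyl carbon gives the lower number, and by how much.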